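Pyrrolidin-1-yl for cyclopentylamino on the sulfonyl chain

The compounds below may be only part of what the source reports. "The series", "measured", "known", "first", "only" and "open" are said of these compounds alone.

- compound 1 `NC(=O)c1cc(-c2ccccc2)cc2c(C3CCN(S(=O)(=O)CCCNC4CCCC4)CC3)c[nH]c12` | 140 nm/s
- compound 2 `CC1(C)CC(c2c[nH]c3c(C(N)=O)cc(-c4ccccc4)cc23)CCS1(=O)=O` | 330 nm/s
- compound 3 `CC1(C)C[C@H](c2c[nH]c3c(C(N)=O)cc(-c4ccc(F)cc4)cc23)CCS1(=O)=O` | 283 nm/s

All three values come from an ADME assay for permeability, using PAMPA (a higher number here means that the compound crosses the layer faster, a lower number that the compound crosses the layer more slowly), and form the whole of the data so far. Compound 1 stands lowest of the three, with compound 2 and compound 3 both higher by more than the scatter. Compound 4 `NC(=O)c1cc(-c2ccccc2)cc2c(C3CCN(S(=O)(=O)CCCN4CCCC4)CC3)c[nH]c12` has not yet been measured. Its structure departs from compound 1 in one place, pyrrolidin-1-yl in place of cyclopentylamino on a saturated chain carbon, three bonds along the chain from a sulfonyl sulfur and the rest of the molecule is unchanged. Going by the values given here, no two measured compounds differ in one place only, so the data give no direct guide to this change. Neither compound 2 nor compound 3 carries the 3-(cyclopentylamino)propyl group, and their values say little about it. A small rise is expected, with nothing beyond the scatter. The expected step is a 1.2-fold higher number from compound 1 to compound 4 (0.08 log units; within the scatter) and it rests on the structural change alone. Compound 4 is estimated at 170 nm/s with a range of 85 nm/s to 340 nm/s as the likely span of the measurement.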

Compound 4, apparent permeability: 160 nm/s
Beside the measured number, compound 4's estimate is 1.1-fold (0.03 log units) above it; measured number inside the range.
By their numbers in this assay, from the lowest: compounds 1, 4, 3 and 2 (each within the scatter of the next, the first and the last beyond it).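

Going by these compounds alone, this is the first comparison that differs in one place only, and it falls on the 3-(cyclopentylamino)propyl group. In this assay, pyrrolidin-1-yl in place of cyclopentylamino gives a 1.1-fold higher number from compound 1 to compound 4 (0.06 log units; within the scatter), so going from 6 heavy atoms to 5 and from 1 hydrogen-bond donor to 0 at this place leaves the read-out within the scatter. No measured property among the data accounts for this result.

Going by these compounds, whether this tolerance extends to other groups at the end of the chain, such as a morpholine, a primary amine or a carboxylic acid, remains open. On these data alone, a shorter or longer chain in place of the propyl link also remains open, as does the same exchange on a different core.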